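Oxan-4-yl in place of pyridin-4-yl on the isoindoline

This account rests on a few compounds, and the source may have more. Where it says the series, first, only, none or still open, it means among the compounds named here.

Measured compounds:
compound 1, `C[C@H](Oc1ccc(S(C)(=O)=O)cc1C(=O)N1Cc2ccccc2C1)C(F)(F)F`, 2540 nM
compound 2, `C[C@H](Oc1ccc(S(C)(=O)=O)cc1C(=O)N1Cc2ccc(-c3ccccn3)cc2C1)C(F)(F)F`, 84 nM
compound 3, `C[C@H](Oc1ccc(S(C)(=O)=O)cc1C(=O)N1Cc2ccc(-c3ccncc3)cc2C1)C(F)(F)F`, 17 nM

All three share one core and differ only in the group carried on the fused ring. In an assay on CHO cells for inhibition of sodium- and chloride-dependent glycine transporter 1 (Homo sapiens), read by scintillation counting (a lower number here means that less compound is needed, a higher number that more compound is needed for the effect), compound 3 gives the lowest number of the three. The nearest is compound 2, with a 4.9-fold lower number from compound 2 to compound 3 (0.69 log units; beyond the scatter) separating them; compound 1 lies furthest, with a 150-fold lower number from compound 1 to compound 3 (2.17 log units; beyond the scatter).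

Compound 4, `C[C@H](Oc1ccc(S(C)(=O)=O)cc1C(=O)N1Cc2ccc(C3CCOCC3)cc2C1)C(F)(F)F`, is not yet measured. It differs from compound 3 in one place: oxan-4-yl in place of pyridin-4-yl on an aromatic carbon.

Among the measured compounds shown here, two measured steps bear on this change. The step of a 30-fold lower number from compound 1 to compound 2 (1.48 log units; beyond the scatter) and the step of a 150-fold lower number from compound 1 to compound 3 (2.17 log units; beyond the scatter) show that adding a six-membered ring at this carbon lowers the number strongly, and the step of a 4.9-fold lower number from compound 2 to compound 3 (0.69 log units; beyond the scatter) shows that the choice of ring matters by a modest amount. The oxan-4-yl ring keeps the size of the pyridin-4-yl ring and one hydrogen-bond acceptor but gives up the aromatic ring, so a modest rise in the number is expected, well short of a return to compound 1.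

Compound 4 is therefore expected to give about 60 nM in this assay, within 17 nM to 220 nM, an estimated step of a 3.5-fold higher number from compound 3 to compound 4 (0.55 log units; beyond the scatter).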

Compound 4, half-maximal effective concentration: 14 nM
Compound 4: middle estimate off by 4.3-fold (0.63 log units), on the high side; the measured number lies below the stated range.
By their numbers in this assay, from the lowest: compounds 4 and 3 (each within the scatter of the next); then compound 2; then compound 1.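

In this assay the step of a 1.2-fold lower number from compound 3 to compound 4 (0.08 log units; within the scatter) shows that this carbon tolerates a non-aromatic ring: oxan-4-yl, a six-membered non-aromatic ring with an oxygen, cannot be told apart from pyridin-4-yl, a six-membered aromatic ring with a nitrogen. Measured against the hydrogen of compound 1, the step of a 180-fold lower number from compound 1 to compound 4 (2.26 log units; beyond the scatter) shows that the large gain seen with the two pyridine rings does not require an aromatic ring at this carbon, which compound 2 and compound 3 alone could not show. The step of a 6.0-fold lower number from compound 2 to compound 4 (0.78 log units; beyond the scatter) leaves pyridin-2-yl as the ring that stands apart from the other two, so ring type alone does not order the compounds shown, and compound 2 goes against any rule that aromatic rings behave alike here.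

On these data alone, what a cyclohexyl ring, with carbon only, would give at this carbon remains open, and so does the question of whether the ring's hetero atom matters at all. Also open, as far as these compounds go, are the effects of a piperidin-4-yl ring, which carries an amine, and of an open chain such as methoxyethyl. Nothing measured here accounts for the match between the oxan-4-yl and pyridin-4-yl rings.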